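Piperazine substituent change on the shared core

The compounds below may be only part of what the source reports. "The series", "measured", "known", "first", "only" and "open" are said of these compounds alone.

Compound 1 `COc1ccc(-c2cnc3nc(N)nc(N4CCN(C(=O)NCc5ccccc5)CC4)c3n2)cc1OC` is the reference point of this small set. In a functional assay on cells (T-cell, Homo sapiens) for inhibition (on this read-out higher numbers stand for weaker inhibition and lower numbers for stronger inhibition), compound 1 gives 18 nM. Compound 2 `COc1ccc(-c2cnc3nc(N)nc(NC(C)C)c3n2)cc1OC` carries an isopropylamino group where compound 1 carries the substituted piperazine; in this assay compound 2 gives 600 nM. Among the compounds with values here, no step between these two is recorded, and their two values simply show that compound 1 stands at the lower number of the pair, with compound 2 a long way above it.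

Compound 3 `COc1ccc(-c2cnc3nc(N)nc(N4CCN(Cc5ccccc5F)CC4)c3n2)cc1OC` has not yet been measured in this assay. It differs from compound 1 in one place: 2-fluorobenzyl in place of benzylcarbamoyl on an amine nitrogen in a ring. The change removes the benzylcarbamoyl group, with its one donor and one acceptor, and puts a 2-fluorobenzyl group directly on the ring nitrogen. Within the data shown here, nothing among the measured compounds shows what this particular exchange does, so the direction rests on the expectation that the piperazine with a large group keeps most of the value of compound 1. The step from compound 1 to compound 3 is expected to be a 3.3-fold higher number from compound 1 to compound 3 (0.52 log units; beyond the scatter), a moderate loss that could reach beyond the scatter. Compound 3 is accordingly estimated at 60 nM, within a range from 12 nM to 300 nM.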

Compound 3, half-maximal inhibitory concentration: 700 nM
The estimate for compound 3 lay 12-fold (1.07 log units) below the measured number, outside the stated range (above it).
By their numbers in this assay, from the lowest: compound 1; then compounds 2 and 3 (each within the scatter of the next).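

Exchanging benzylcarbamoyl for 2-fluorobenzyl on the ring nitrogen of the substituted piperazine gives a 39-fold higher number from compound 1 to compound 3 (1.59 log units; beyond the scatter) in this assay, so the number at this position depends strongly on the group attached there. A piperazine bearing a large group with an aromatic ring is therefore not enough to retain the number of compound 1: compound 2 at 600 nM and compound 3 at 700 nM lie within the scatter of each other, even though compound 2 carries isopropylamino in place of the piperazine. Nothing available accounts for this loss.

This single exchange removes the carbonyl and the amide hydrogen and introduces fluorine at the same time, so the compounds shown cannot assign the step to any one of these parts. An unsubstituted benzyl group on the same nitrogen would separate the fluorine from the rest of the exchange, while a benzoyl group would show what a carbonyl without the amide hydrogen does at this position.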